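Aryl variation at the saturated ring carbon of the core

A few compounds are considered here, and "the series" means these few. Any claim that something is new, unique, unknown or untested is made for them only; others in the source may bear on it.

Measured so far in a functional assay on Ehrlich cells (Mus musculus) for cytotoxicity; on this read-out higher numbers stand for weaker inhibition and lower numbers for stronger inhibition:
compound 1 `COc1cc(N2C(N)=C(C#N)C(/C=C/c3ccccc3)C3=C2CC(C)(C)CC3=O)cc(OC)c1OC`: "not active" (no number reported)
compound 2 `COc1cc(N2C(N)=C(C#N)C(c3c(O)ccc4ccccc34)C3=C2CC(C)(C)CC3=O)cc(OC)c1OC`: 143000 nM
compound 3 `COc1cc(N2C(N)=C(C#N)C(c3ccc(Cl)cc3Cl)C3=C2CC(C)(C)CC3=O)cc(OC)c1OC`: 94700 nM

Compound 1 gives no number; the shared core with a styryl-type substituent is simply reported as inactive. For the measured compounds named here, compound 2 and compound 3 do give numbers, and the only step between them, a 1.5-fold lower number from compound 2 to compound 3 (0.18 log units; within the scatter), lies within the scatter, so neither compound separates from the other, and compound 3 stands beside compound 2 rather than apart from it.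

Compound 4 `COc1cc(N2C(N)=C(C#N)C(c3ccc(C)o3)C3=C2CC(C)(C)CC3=O)cc(OC)c1OC` is the next variation at the same position. The change from compound 3 is 5-methylfuran-2-yl in place of 2,4-dichlorophenyl on a saturated ring carbon.

Going by the values given here, the only measured step that bears on this change is the one at the same saturated ring carbon, from compound 2 to compound 3, which was within the scatter despite a large change of substituent. On that basis no movement beyond the scatter is expected for the change to compound 4, in either direction; the unresolved reading of compound 1 is a reminder that a non-number is also possible. Compound 4 is expected near the values of compound 2 and compound 3, at 110000 nM with a range from 40000 nM to 300000 nM, which means an estimated step of a 1.2-fold higher number from compound 3 to compound 4 (0.07 log units; within the scatter).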

Compound 4, half-maximal inhibitory concentration: 216000 nM
For compound 4 the middle estimate is 2.0-fold (0.29 log units) below the measured one; measured number inside the range.
By their numbers in this assay, from the lowest: compounds 3, 2 and 4 (each within the scatter of the next, the first and the last beyond it).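

In this assay the saturated ring carbon gives its first step beyond the scatter: the change to 5-methylfuran-2-yl yields a 2.3-fold higher number from compound 3 to compound 4 (0.36 log units; beyond the scatter) and so separates the two ends of the numbered compounds, although the step is modest. The replacement of 2-hydroxynaphthalen-1-yl by the same group gives a 1.5-fold higher number from compound 2 to compound 4 (0.18 log units; within the scatter) and does not separate those two compounds, so compound 2 stands within the scatter of both compound 3 and compound 4, and the three do not fall into distinct groups. Nothing measured here accounts for the gap between 2,4-dichlorophenyl and 5-methylfuran-2-yl.

Steps to compound 1 cannot be read, as it has no number, so the place of its styryl-type substituent relative to the aryl and furyl groups remains open. Also open, going by these compounds, is whether a group of another kind on this carbon, such as a carboxylic acid, an amine or a longer alkyl chain, would move the number well away from those of compound 2, compound 3 and compound 4.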